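Mirror-image pair in a hydroxypyrrolidine sulfone series

The compounds below may be only part of what the source reports. "The series", "measured", "known", "first", "only" and "open" are said of these compounds alone.

Measured so far:
compound 1 `N#Cc1ccc(S(=O)(=O)[C@H]2CN(S(=O)(=O)c3ccc(Cl)cc3Cl)C[C@@H]2O)cc1`, 25 nM
compound 2 `N#Cc1ccc(S(=O)(=O)[C@@H]2CN(S(=O)(=O)c3ccc(Cl)cc3Cl)C[C@@]2(O)CO)cc1`, 1590 nM

In an assay on cells for antagonist activity at transient receptor potential cation channel subfamily V member 4 (Homo sapiens), read by FLIPR and calcium flux, with a stated time of 10 min (on this read-out lower numbers stand for stronger inhibition and higher numbers for weaker inhibition), compound 2 gives the highest of the two numbers; its nearest neighbour is compound 1, whose number is far lower, a gap beyond the scatter. Compound 3 `N#Cc1ccc(S(=O)(=O)[C@H]2CN(S(=O)(=O)c3ccc(Cl)cc3Cl)C[C@]2(O)CO)cc1` is the mirror image of compound 2: the two compounds have the same atoms and bonds and differ only in configuration as drawn: 2 of 2 stereo elements differ (all stereocentres are inverted: mirror images); a stereocentre at a saturated ring carbon is drawn R in compound 2 and S in compound 3; a stereocentre at a saturated ring carbon is drawn R in compound 2 and S in compound 3. Going by the values given here, no step between measured compounds covers a change of this kind, so the direction rests on the general observation that mirror images can differ widely. Compound 3 is expected to show the step of an 11-fold lower number from compound 2 to compound 3 (1.03 log units; beyond the scatter), with its estimated value at 150 nM, within a range of 20 nM to 1200 nM.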

Compound 3, half-maximal inhibitory concentration: 50 nM
Estimate against measurement, compound 3: 3.0-fold (0.48 log units) above; measured number inside the range.
By their numbers in this assay, from the lowest: compounds 1 and 3 (each within the scatter of the next); then compound 2.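

In this assay, inverting both stereocentres gives a 32-fold lower number from compound 2 to compound 3 (1.50 log units; beyond the scatter), so configuration alone separates this mirror-image pair: the fact that compounds 2 and 3 differ only in the configuration as drawn. Hydroxymethyl in place of hydrogen on a saturated ring carbon gives a 2.0-fold higher number from compound 1 to compound 3 (0.30 log units; within the scatter), so in the configuration of compound 3 this group leaves the number within the scatter of compound 1. The large penalty seen for compound 2 therefore belongs to one configuration, not to the hydroxymethyl group as such. As far as these compounds go, whether an aminomethyl group, a carboxylic acid or a longer hydroxyalkyl chain at this carbon would behave like hydroxymethyl remains open. From the compounds shown here alone, the mirror image of compound 1 also remains open, so the size of the configuration effect without hydroxymethyl is unknown.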